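Four stereoisomers of a shared core, all weakly active

This account rests on a few compounds, and the source may have more. Where it says the series, first, only, none or still open, it means among the compounds named here.

Compounds 1, 2 and 3 share the same atoms and bonds and differ only in the configuration at two ring carbons: compound 1 is `N=C(N)NCCCCNC(=O)/C=C/c1ccc2c(c1)[C@@H](C(=O)NCCCCNC(=N)N)[C@H](c1ccc(O)cc1)O2`, compound 2 is `N=C(N)NCCCCNC(=O)/C=C/c1ccc2c(c1)[C@@H](C(=O)NCCCCNC(=N)N)[C@@H](c1ccc(O)cc1)O2`, and compound 3 is `N=C(N)NCCCCNC(=O)/C=C/c1ccc2c(c1)[C@H](C(=O)NCCCCNC(=N)N)[C@@H](c1ccc(O)cc1)O2`. In a functional assay on Caudal artery for antagonist activity at Alpha-1A adrenergic receptor (Rattus norvegicus) (on this read-out lower numbers stand for stronger inhibition and higher numbers for weaker inhibition), compound 1 gives 14300000 nM, compound 2 gives 17700000 nM, and compound 3 gives 19300000 nM. Compound 3 thus has the highest of the three numbers, but the step of a 1.3-fold higher number from compound 1 to compound 3 (0.13 log units; within the scatter) and the step of a 1.1-fold higher number from compound 2 to compound 3 (0.04 log units; within the scatter) both lie within the scatter, as does a 1.2-fold higher number from compound 1 to compound 2 (0.09 log units; within the scatter); the stereochemical nature of each step is noted in the fact that one of compounds 1 and 2 is drawn with a defined configuration and the other without, at the place where they differ, the fact that one of compounds 1 and 3 is drawn with a defined configuration and the other without, at the place where they differ and (the fact that one of compounds 2 and 3 is drawn with a defined configuration and the other without, at the place where they differ).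

Compound 4 is `N=C(N)NCCCCNC(=O)/C=C/c1ccc2c(c1)[C@H](C(=O)NCCCCNC(=N)N)[C@H](c1ccc(O)cc1)O2`, the fourth stereoisomer. Compared with compound 3, (the two compounds have the same atoms and bonds; at least one stereo element is drawn with a configuration in one of them and without one in the other: 1 of 5 stereo elements differ; a stereocentre at a saturated ring carbon is drawn S in compound 3 and R in compound 4). Every measured swap of a ring stereocentre in this set moved this assay only within the scatter, so no change beyond the scatter is expected here either. Compound 4 is therefore estimated at 17000000 nM, with a range from 9000000 nM to 32000000 nM. The expected step is a 1.1-fold lower number from compound 3 to compound 4 (0.06 log units; within the scatter).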

Compound 4, half-maximal inhibitory concentration: 4900000 nM
The estimate for compound 4 lay 3.5-fold (0.54 log units) above the measured number; measured number outside the range, below it.
By their numbers in this assay, from the lowest: compound 4; then compounds 1, 2 and 3 (each within the scatter of the next).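

Ring configuration is not silent in this assay after all: the steps are a 3.9-fold lower number from compound 3 to compound 4 (0.60 log units; beyond the scatter), a 3.6-fold lower number from compound 2 to compound 4 (0.56 log units; beyond the scatter) and a 2.9-fold lower number from compound 1 to compound 4 (0.47 log units; beyond the scatter), all beyond the scatter, though modest. The effect of one ring carbon also depends on the other, since the same carbon is swapped in a 1.2-fold higher number from compound 1 to compound 2 (0.09 log units; within the scatter), which stays within the scatter, and in a 3.9-fold lower number from compound 3 to compound 4 (0.60 log units; beyond the scatter), which does not. The two compounds of that last step share all atoms and bonds, so the shift can only be tied to configuration: the fact that one of compounds 3 and 4 is drawn with a defined configuration and the other without, at the place where they differ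

The compounds shown leave open whether this dependence on configuration would survive a change elsewhere in the molecule, such as an amine in place of each guanidine or a longer chain in place of the butyl linkers. They also leave open whether a methoxy group in place of the phenol hydroxyl would alter these numbers.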